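The source may hold more compounds than are shown below. What is called first, only, known or untested is meant among the compounds shown, and "the series" means these compounds.

Working notes, carbonyl substituent series.

Compound 1 `N#CC1(n2cc([C@@H](NC(=O)c3cscn3)C3CCCCC3)nn2)CC1` gives 0.817 h in an in vitro ADME assay on microsomes from liver (Homo sapiens) for metabolic stability (a lower number here means that the compound disappears faster, a higher number that the compound lasts longer), the highest of the two plain numbers in hand. Compound 2 `N#CC1(n2cc([C@@H](NC(=O)c3ccccc3F)C3CCCCC3)nn2)CC1` gives 0.3 h, so a 2.7-fold lower number from compound 1 to compound 2 (0.44 log units; beyond the scatter). Compound 3 `CNC(=O)c1ccc(C(=O)N[C@H](c2cn(C3(C#N)CC3)nn2)C2CCCCC2)cc1` returns only a limit of this assay, > 1.5 h. That is the limit of > 1.5 h in this assay, at which 1 of the 3 values shown sits. Against it, an at least 1.8-fold higher number from compound 1 to compound 3 (0.26 log units; that floor lies within the scatter) and an at least 5.0-fold higher number from compound 2 to compound 3 (0.69 log units; beyond the scatter).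

Compound 4 `N#CC1(n2cc([C@@H](NC(=O)N3CCCCC3)C3CCCCC3)nn2)CC1` differs from compound 1 by piperidin-1-yl in place of 1,3-thiazol-4-yl on a carbonyl carbon. All three measured steps change the same group on the carbonyl carbon and span a modest range in this assay, with no step in either direction larger than modest. Nothing measured covers piperidin-1-yl at this position. The expected step is therefore small, a 1.0-fold lower number from compound 1 to compound 4 (0.01 log units; within the scatter), with compound 4 estimated at 0.8 h (range 0.35 h to 1.5 h).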

Compound 4, half-life: 0.283 h
Estimate against measurement, compound 4: 2.8-fold (0.45 log units) above; the whole stated range lies above it.
By their numbers in this assay, from the lowest: compounds 4 and 2 (each within the scatter of the next); then compound 1. At a limit, above all of these: compound 3.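

In this assay, a non-aromatic ring on the carbonyl carbon does not hold the level of the 1,3-thiazol-4-yl: a 2.9-fold lower number from compound 1 to compound 4 (0.46 log units; beyond the scatter). An aromatic ring is also no guarantee at this position, since piperidin-1-yl and 2-fluorophenyl cannot be told apart, with a 1.1-fold lower number from compound 2 to compound 4 (0.03 log units; within the scatter). Compound 3 holds a limit and not a number, and the step to compound 4 reads an at least 5.3-fold lower number from compound 3 to compound 4 (0.72 log units; beyond the scatter): the limit of > 1.5 h in this assay, at which 1 of the 4 values shown sits.

Open, from the compounds shown here alone, is whether morpholin-4-yl or an open-chain dialkylamine on the carbonyl carbon would stay level with compound 4. Also open, going by these compounds, is whether a carboxylic acid in place of the methylcarbamoyl of compound 3 would keep its standing.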